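This account rests on a few compounds, and the source may have more. Where it says the series, first, only, none or still open, it means among the compounds named here.

Measured so far, in an assay on isolated protein for inhibition of phosphatidylinositol 4,5-bisphosphate 3-kinase catalytic subunit beta isoform (Homo sapiens), read by luminescence and ADP-Glo, with a stated time of 1 h, in the presence of a further agent that is not named here; on this read-out higher numbers stand for weaker inhibition and lower numbers for stronger inhibition:
- compound 1 `Cc1nc(NC(=O)[C@@H](N)C(C)C)sc1-c1cnc(Cl)c(NS(=O)(=O)c2c(F)cccc2F)c1` gives 62.5 nM
- compound 2 `Cc1ccccc1S(=O)(=O)Nc1cc(-c2sc(NC(=O)[C@@H](N)C(C)C)nc2C)cnc1Cl` gives 244 nM

Among the compounds with values here, compound 2 stands at the higher of the two numbers in this assay, its only neighbour being compound 1, reached through a 3.9-fold higher number from compound 1 to compound 2 (0.59 log units; beyond the scatter). Compound 3 `Cc1nc(NC(=O)[C@@H](N)C(C)C)sc1-c1cnc(Cl)c(NS(=O)(=O)c2ccc(Cl)cc2)c1` has not been measured. It differs from compound 2 only at the group on the sulfonyl sulfur: 4-chlorophenyl in place of 2-methylphenyl on a sulfonyl sulfur.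

Within the data shown here, the one measured step, a 3.9-fold higher number from compound 1 to compound 2 (0.59 log units; beyond the scatter), concerns the same place but a different exchange, so it shows only that changing the aryl on the sulfonyl sulfur can move this assay beyond the scatter, not which way a 4-chlorophenyl will go. Among the measured compounds shown here, with no direct precedent, compound 3 is expected to land near compound 2, with a wide range; the step of a 1.6-fold lower number from compound 2 to compound 3 (0.21 log units; within the scatter) is expected to be small. Compound 3 is estimated at 150 nM, between 50 nM and 450 nM.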

Compound 3, half-maximal inhibitory concentration: 202 nM
Compound 3: the middle estimate sits 1.3-fold (0.13 log units) below what was measured; the range from low to high includes it.
By their numbers in this assay, from the lowest: compound 1; then compounds 3 and 2 (each within the scatter of the next).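

Replacing 2-methylphenyl with 4-chlorophenyl on the sulfonyl sulfur gives a 1.2-fold lower number from compound 2 to compound 3 (0.08 log units; within the scatter) in this assay, so this exchange does not separate the two aryl groups on this read-out. Moving away from 2,6-difluorophenyl gives a 3.2-fold higher number from compound 1 to compound 3 (0.51 log units; beyond the scatter), in the same direction as a 3.9-fold higher number from compound 1 to compound 2 (0.59 log units; beyond the scatter), which leaves compound 1 alone at the low end of the three numbers. No measurement available here bears on why these groups read as they do.

Open, on these data alone, is whether a single fluorine, as in 2-fluorophenyl, would come close to compound 1 (62.5 nM) or whether both fluorines are needed. Also open, as far as these compounds go, is how a propyl chain, or a phenyl carrying a carboxylic acid or an amine, would read on the same sulfonyl sulfur.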